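Replacing the side chain of compound 2

The compounds below may be only part of what the source reports. "The series", "measured", "known", "first", "only" and "open" are said of these compounds alone.

compound 1 `COc1cc(OC)c2c(=O)c(OCCCCN3CCCC3)c(-c3cc(OC)c(OC)c(OC)c3)oc2c1`: 26800 nM
compound 2 `COc1cc(OC)c2c(=O)c(OCC(=O)N/N=C/c3ccccc3F)c(-c3cc(OC)c(OC)c(OC)c3)oc2c1`: 7720 nM
compound 3 `COc1cc(OC)c2c(=O)c(OCC(=O)N/N=C/c3ccc[nH]3)c(-c3cc(OC)c(OC)c(OC)c3)oc2c1`: 8730 nM

In a functional assay on SGC-7901 cells (Homo sapiens) for cytotoxicity, read by MTT assay, with a stated time of 38 h (on this read-out lower numbers stand for stronger inhibition and higher numbers for weaker inhibition), compound 2, at 7720 nM, sits within the scatter of compound 3, at 8730 nM. Both lie beyond the scatter under compound 1. Compound 4 `COc1cc(OC)c2c(=O)c(OCCCCN3CCN(C)CC3)c(-c3cc(OC)c(OC)c(OC)c3)oc2c1` differs from compound 2 by a group of 10 heavy atoms (8 carbon, 2 nitrogen; one six-membered non-aromatic ring with 2 hetero atoms) in place of a group of 12 heavy atoms (8 carbon, 2 nitrogen, 1 oxygen, 1 fluorine; one six-membered aromatic ring of carbon only), on a saturated chain carbon bound to an oxygen on an aromatic ring. Compound 1 also carries a non-aromatic ring in that place. The measured steps that bear on the change are a 3.5-fold lower number from compound 1 to compound 2 (0.54 log units; beyond the scatter) and a 3.1-fold lower number from compound 1 to compound 3 (0.49 log units; beyond the scatter), both modest. A step of similar size in the opposite direction, toward a higher number, is therefore expected in this assay. The expected step is a 2.6-fold higher number from compound 2 to compound 4 (0.41 log units; beyond the scatter). For compound 4 the estimated value is 20000 nM, with an expected range of 8000 nM to 50000 nM.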

Compound 4, half-maximal inhibitory concentration: 6950 nM
Compound 4: the middle estimate sits 2.9-fold (0.46 log units) above what was measured; the measured number lies below the stated range.
By their numbers in this assay, from the lowest: compounds 4, 2 and 3 (each within the scatter of the next); then compound 1.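

In this assay, a side chain carrying a non-aromatic ring proves able to match the chains carrying an aromatic ring, with 3-(4-methylpiperazin-1-yl)propyl giving a 1.1-fold lower number from compound 2 to compound 4 (0.05 log units; within the scatter) and a 1.3-fold lower number from compound 3 to compound 4 (0.10 log units; within the scatter), both within the scatter. The non-aromatic ring itself therefore matters on this chain: 4-methylpiperazin-1-yl in place of pyrrolidin-1-yl gives a 3.9-fold lower number from compound 1 to compound 4 (0.59 log units; beyond the scatter). No available evidence explains this difference.

Which feature of the 4-methylpiperazin-1-yl group carries that step remains open. Piperidin-1-yl, morpholin-4-yl or unmethylated piperazin-1-yl on the same chain would help separate them.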